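Methoxy in Place of Chloro on the Benzamide of Compound 2

The compounds below may be only part of what the source reports. "The series", "measured", "known", "first", "only" and "open" are said of these compounds alone.

In an assay on microsomes from liver for inhibition of sterol O-acyltransferase 1 (Rattus norvegicus) (on this read-out lower numbers stand for stronger inhibition and higher numbers for weaker inhibition), the measured compounds stand as follows:
compound 1 `CCCCCCCCCCCCn1nnc(C(NC(=O)c2ccccc2)c2ccccc2)n1` gives 350 nM
compound 2 `CCCCCCCCCCCCn1nnc(C(NC(=O)c2ccc(Cl)cc2)c2ccccc2)n1` gives 440 nM

For the measured compounds named here, compound 2 has the higher of the two numbers, but its only neighbour is compound 1, and the step of a 1.3-fold higher number from compound 1 to compound 2 (0.10 log units; within the scatter) stays within the scatter, so the two cannot be ordered. Compound 3 `CCCCCCCCCCCCn1nnc(C(NC(=O)c2ccc(OC)cc2)c2ccccc2)n1` differs from compound 2 by methoxy in place of chloro on an aromatic carbon. Going by the values given here, the one measured step that bears on this place, a 1.3-fold higher number from compound 1 to compound 2 (0.10 log units; within the scatter), was small, so no step beyond the scatter is expected, a 1.1-fold lower number from compound 2 to compound 3 (0.04 log units; within the scatter). Compound 3 is therefore estimated at 400 nM, within 200 nM to 800 nM.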

Compound 3, half-maximal inhibitory concentration: 600 nM
Beside the measured number, compound 3's estimate is 1.5-fold (0.18 log units) below it, within the range that was stated.
By their numbers in this assay, from the lowest: compounds 1, 2 and 3 (each within the scatter of the next).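

Exchanging 4-chlorophenyl for 4-methoxyphenyl in this assay gives a 1.4-fold higher number from compound 2 to compound 3 (0.13 log units; within the scatter), and methoxy in place of hydrogen gives a 1.7-fold higher number from compound 1 to compound 3 (0.23 log units; within the scatter). A third group at this place, on an aromatic carbon para to a large group, and one that brings a hydrogen-bond acceptor, thus still leaves all the compounds within the scatter of one another, so this position has not yet separated any of them. Going by these compounds, whether an amine or a carboxylic acid here would give a step beyond the scatter stays open. Nothing at hand speaks to what lies behind these numbers.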